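The source may hold more compounds than are shown below. What is called first, only, known or untested is meant among the compounds shown, and "the series" means these compounds.

In an in vitro functional assay on cells for agonist activity at Bombesin receptor subtype-3 (Homo sapiens), read by luminescence and calcium flux (on this read-out higher numbers stand for an effect only at larger amounts of compound and lower numbers for an effect already at smaller amounts), compound 1 `O=C(O)c1ccccc1-c1ccc(CCc2ncc(CC3CCC3)[nH]2)cc1` gives 588 nM.
In this assay compound 2 `COc1cccc(Cc2cnc(CCc3ccc(-c4ccccc4C(=O)O)cc3)[nH]2)c1` gives 4120 nM.
In this assay compound 3 `CC(C)(C)c1cnc(CCc2ccc(-c3ccccc3C(=O)O)cc2)[nH]1` gives 4330 nM.

Among these three numbers compound 2 stands second highest. Its nearest neighbour is compound 3, with a 1.1-fold higher number from compound 2 to compound 3 (0.02 log units; within the scatter), a gap within the scatter, so the two cannot be told apart. Its furthest neighbour is compound 1, with a 7.0-fold higher number from compound 1 to compound 2 (0.85 log units; beyond the scatter), a gap beyond the scatter.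

Compound 4 `O=C(O)c1ccccc1-c1ccc(CCc2ncc(Cc3ccccc3)[nH]2)cc1` differs from compound 2 in one place: hydrogen in place of methoxy on an aromatic carbon. For the measured compounds named here, no measured step removes a methoxy on its own. The two steps that touch this part of the shared core, a 7.0-fold higher number from compound 1 to compound 2 (0.85 log units; beyond the scatter) and a 1.1-fold higher number from compound 2 to compound 3 (0.02 log units; within the scatter), each exchange the whole group, so they give only a loose guide; the smaller of the two steps also sits within the scatter. The expected step of a 1.4-fold lower number from compound 2 to compound 4 (0.14 log units; within the scatter) is therefore small, without a clear direction beyond the scatter. For compound 4 the estimate in this assay is 3000 nM, expected to fall between 1000 nM and 9000 nM.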

Compound 4, half-maximal effective concentration: 205 nM
Compound 4: middle estimate off by 15-fold (1.17 log units), on the high side; measured number below the stated range.
By their numbers in this assay, from the lowest: compound 4; then compound 1; then compounds 2 and 3 (each within the scatter of the next).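

Taking the methoxy off the 3-methoxybenzyl group and leaving hydrogen in its place gives a 20-fold lower number from compound 2 to compound 4 (1.30 log units; beyond the scatter) in this assay, so this single group on the aromatic carbon matters far more than its small size might suggest. The benzyl group also compares well with other groups at this part of the molecule, with a 21-fold lower number from compound 3 to compound 4 (1.32 log units; beyond the scatter) for benzyl in place of tert-butyl and a 2.9-fold lower number from compound 1 to compound 4 (0.46 log units; beyond the scatter) for phenyl in place of cyclobutyl on the same chain carbon. No measurement available here explains why one methoxy shifts the number so strongly.

As far as these compounds go, it remains open whether a group such as methyl, fluorine or an amine on the same aromatic carbon would behave like methoxy or like hydrogen. It is also unknown whether a methoxy elsewhere on this ring would have the same effect.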